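Chloro on the pendant phenyl in two quinoline amide series

The source may report more compounds than this note shows. Statements on the series, on what has been measured and on what is new or still open speak of the compounds shown alone.

This account concerns four compounds that share a large common scaffold and differ in small ways. Compound 1 has the structure `COc1cc2c(Oc3ccc(NC(=O)c4cc(-c5cccc(Cl)c5)nc5ccccc45)cc3F)ccnc2cc1OCCCN1CCC(C)CC1` and compound 2 the structure `COc1cc2c(Oc3ccc(NC(=O)c4cc(-c5ccccc5)nc5ccccc45)cc3F)ccnc2cc1OCCCN1CCC(C)CC1`; the two differ by chloro in place of hydrogen on an aromatic carbon. In a functional assay on HT-29 cells (Homo sapiens) for cytotoxicity, read by MTT assay, with a stated time of 72 h (on this read-out higher numbers stand for weaker inhibition and lower numbers for stronger inhibition), compound 2 gives 120 nM, and compound 1 gives 100 nM, so the step is a 1.2-fold lower number from compound 2 to compound 1 (0.08 log units; within the scatter).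

Compound 3 has the structure `COc1cc2c(Oc3ccc(NC(=O)c4cc(-c5ccccc5)nc5ccc(F)cc45)cc3F)ccnc2cc1OCCCN1CCCC1` and belongs to a second core, which carries a fluorine on the fused ring and a different amine on the chain; the difference between the two cores is not broken down here. In this assay compound 3 gives 160 nM, a number that sits within the scatter of both compound 2 and compound 1, so no order among the three can be read from these values.

Compound 4, with the structure `COc1cc2c(Oc3ccc(NC(=O)c4cc(-c5cccc(Cl)c5)nc5ccc(F)cc45)cc3F)ccnc2cc1OCCCN1CCCC1`, has not been measured. It differs from compound 3 by chloro in place of hydrogen on an aromatic carbon, the same change that separates compound 2 from compound 1, made at the same place. Because the earlier step was a 1.2-fold lower number from compound 2 to compound 1 (0.08 log units; within the scatter), the expected step from compound 3 to compound 4 is estimated at a 1.2-fold lower number from compound 3 to compound 4 (0.09 log units; within the scatter). The value of compound 4 in this assay is therefore expected to be about 130 nM, with a likely range from 65 nM to 260 nM. This rests on a single earlier step, so the expectation is held loosely.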

Compound 4, half-maximal inhibitory concentration: 670 nM
Compound 4: the middle estimate sits 5.2-fold (0.71 log units) below what was measured, outside the stated range (above it).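

In this assay, the change from phenyl to 3-chlorophenyl does not carry over unchanged between the two cores: on the fluorine-bearing core it gives a 4.2-fold higher number from compound 3 to compound 4 (0.62 log units; beyond the scatter), whereas on the core of compound 2 the same change stayed within the scatter. Set side by side, the two steps differ by more than the scatter of such steps, so in this small set the outcome of adding this chloro depends on the core that carries it: the same change on two cores in this assay, a 1.2-fold lower number (0.08 log units; within the scatter) from compound 2 to compound 1 and a 4.2-fold higher number (0.62 log units; beyond the scatter) from compound 3 to compound 4, 5.0-fold (0.70 log units) apart, beyond the scatter of two such steps This does not show which feature of the core is responsible, and with only one pair on each core it gives no general rule for how this change behaves elsewhere in the series.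

The two cores differ both in the fluorine on the fused ring and in the amine on the chain, so the compounds shown leave open which of these two differences goes with the divergence, a question that a compound carrying only one of them could settle. From the compounds shown here alone, it also remains open whether a bromo or a methoxy group in the same place on the phenyl would split between the two cores as chloro does.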